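The source may report more compounds than this note shows. Statements on the series, on what has been measured and on what is new or still open speak of the compounds shown alone.

Measured so far:
compound 1 `COc1cc(OC)c(OC)cc1/C=C/C(=O)c1cc(Cc2ccccc2)cc(Cc2ccccc2)c1` gives 26900 nM
compound 2 `COc1cc(OC)c(OC)cc1/C=C/C(=O)c1ccc(O)cc1O` gives 37600 nM
compound 3 `COc1cc(OC)c(C(=O)/C=C/c2cc(OC)c(OC)cc2OC)c(OC)c1` gives 108000 nM

All three numbers come from a functional assay on HeLa cells (Homo sapiens) for inhibition, read by MTT assay, with a stated time of 72 h; on this read-out lower numbers stand for stronger inhibition and higher numbers for weaker inhibition. Compound 2 holds the second highest of the three numbers; its gap to compound 1 lies within the scatter, so no order between those two can be read, whereas compound 3 sits beyond the scatter at a higher number. Within the data shown here, no step between measured compounds that differ in one place is available, so the next change has no measured precedent. Compound 4 `COc1cc(OC)c(OC)cc1/C=C/C(=O)c1ccc(Cl)cc1` differs from compound 2 in one place: 4-chlorophenyl in place of 2,4-dihydroxyphenyl on a carbonyl carbon. The expected step in this assay is a modest move towards a lower number, possibly not clearing the scatter. For compound 4 the estimate is 20000 nM, ranging from 5000 nM to 80000 nM. The expected step from compound 2 to compound 4 is a 1.9-fold lower number from compound 2 to compound 4 (0.27 log units; within the scatter).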

Compound 4, half-maximal inhibitory concentration: 36500 nM
Estimate against measurement, compound 4: 1.8-fold (0.26 log units) below; the range from low to high includes it.
By their numbers in this assay, from the lowest: compounds 1, 4 and 2 (each within the scatter of the next); then compound 3.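

First one-place step in the series: in this assay, the step is a 1.0-fold lower number from compound 2 to compound 4 (0.01 log units; within the scatter), so on this carbonyl carbon, 4-chlorophenyl and 2,4-dihydroxyphenyl cannot be told apart. The leaving ring has 2 hydrogen-bond donors and 2 hydrogen-bond acceptors and the entering ring has 0 of each, yet this pair shows no separation. Nothing available explains this flat step.

Open: whether an amine or a carboxylic acid on this ring would give a step beyond the scatter. Going by these compounds, also open: whether the same exchange stays flat on another core.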